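Compound 1 to Compound 4: Replacing the Nitrogen Substituent

The source may report more compounds than this note shows. Statements on the series, on what has been measured and on what is new or still open speak of the compounds shown alone.

In a functional assay on HepG2 cells (Homo sapiens) for cytotoxicity, read by sulforhodamine B assay, with a stated time of 48 h (a higher number here means a weaker inhibitor, a lower number a stronger inhibitor), compound 1 `N#Cc1c(-c2ccc(Cl)cc2)cc(-c2ccc(Cl)cc2)n(CC(O)CCl)c1=O` gives 4.8 ug/mL. Compound 2 `N#Cc1c(-c2ccc(Cl)cc2)cc(-c2ccc(Cl)cc2)n([C@@H]2O[C@H](COC(=O)c3ccccc3)[C@@H](OC(=O)c3ccccc3)[C@H]2OC(=O)c2ccccc2)c1=O` gives 8 ug/mL, and compound 3 `CC(=O)OC[C@H]1O[C@@H](n2c(-c3ccc(Cl)cc3)cc(-c3ccc(Cl)cc3)c(C#N)c2=O)[C@H](OC(C)=O)[C@@H](OC(C)=O)[C@@H]1OC(C)=O` gives 7.25 ug/mL, so compound 1 stands within the scatter of both. Compound 4 `N#Cc1c(-c2ccc(Cl)cc2)cc(-c2ccc(Cl)cc2)n([C@@H]2O[C@H](CO)[C@@H](O)[C@H](O)[C@H]2O)c1=O` is still unmeasured. It carries 3,4,5-trihydroxy-6-(hydroxymethyl)oxan-2-yl in place of 3-chloro-2-hydroxypropyl on an aromatic nitrogen. Going by the values given here, no measured pair differs in one place alone. However, compound 2 at 8 ug/mL and compound 3 at 7.25 ug/mL bear other groups on that nitrogen and remain within the scatter of compound 1. No step beyond the scatter is therefore expected in this assay, with a slight lean toward a higher number. The estimate means a step of a 1.7-fold higher number from compound 1 to compound 4 (0.22 log units; within the scatter). For compound 4 the estimated value is 8 ug/mL, with an expected range of 3.5 ug/mL to 18 ug/mL.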

Compound 4, half-maximal inhibitory concentration: 16.1 ug/mL
The estimate for compound 4 lay 2.0-fold (0.30 log units) below the measured number, within the range that was stated.
By their numbers in this assay, from the lowest: compounds 1, 3, 2 and 4 (each within the scatter of the next, the first and the last beyond it).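

In this assay the substituent on the aromatic nitrogen does shift the number: 3,4,5-trihydroxy-6-(hydroxymethyl)oxan-2-yl in place of 3-chloro-2-hydroxypropyl gives a 3.4-fold higher number from compound 1 to compound 4 (0.53 log units; beyond the scatter) and so moves beyond the scatter. The earlier compounds shown here, which all lay within the scatter of one another, showed no such step. Nothing available explains this step. The compounds shown leave open how a simple amine or a carboxylic acid on that nitrogen would read, and whether an unsubstituted propyl chain there would stay close to compound 1.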